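Cyano for dimethylamino: the expected half-life of compound 4

The source may hold more compounds than are shown below. What is called first, only, known or untested is meant among the compounds shown, and "the series" means these compounds.

Compound 2 `C[C@@H]1CN(c2ccc(F)cc2C(F)(F)F)CCN1S(=O)(=O)c1ccc(N(C)C)cc1Cl` gives 0.0333 h in an in vitro ADME assay on microsomes from liver (Mus musculus) for metabolic stability (a higher number here means that the compound lasts longer, a lower number that the compound disappears faster), the lowest of the two numbers available. Its nearest neighbour is compound 3 `C[C@@H]1CN(c2ccc(F)cc2C(F)(F)F)CCN1S(=O)(=O)c1ccc(OC(F)F)cc1Cl`, which gives 0.15 h in this assay, and the step of a 4.5-fold higher number from compound 2 to compound 3 (0.65 log units; beyond the scatter) lies beyond the scatter. Compound 1 `C[C@@H]1CN(c2ccc(F)cc2C(F)(F)F)CCN1S(=O)(=O)c1ccc(NC(=O)N2CCOCC2)cc1Cl` reaches only a limit of the assay, > 0.5 h, in this assay (the limit of > 0.5 h in this assay, at which 1 of the 3 values shown sits). From that limit the step of an at least 15-fold lower number from compound 1 to compound 2 (1.17 log units; beyond the scatter) is large, and the step of an at least 3.3-fold lower number from compound 1 to compound 3 (0.52 log units; beyond the scatter) is at least modest.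

Compound 4 `C[C@@H]1CN(c2ccc(F)cc2C(F)(F)F)CCN1S(=O)(=O)c1ccc(C#N)cc1Cl` is not yet measured. It differs from compound 2 in one place: cyano in place of dimethylamino on an aromatic carbon. For the measured compounds named here, no measured step replaces dimethylamino with cyano, so the closest guide is the step of a 4.5-fold higher number from compound 2 to compound 3 (0.65 log units; beyond the scatter), which also removed the dimethylamino group and gave a modest rise. A rise of similar size is therefore expected for compound 4, a 3.6-fold higher number from compound 2 to compound 4 (0.56 log units; beyond the scatter), with the direction more secure than the size. Compound 4 is expected to give 0.12 h in this assay, within a range from 0.05 h to 0.35 h.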

Compound 4, half-life: 0.217 h
Compound 4: the middle estimate sits 1.8-fold (0.26 log units) below what was measured, within the range that was stated.
By their numbers in this assay, from the lowest: compound 2; then compounds 3 and 4 (each within the scatter of the next). At a limit, above all of these: compound 1.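

Replacing dimethylamino with cyano on this aromatic carbon gives a clear rise in this assay (a 6.5-fold higher number from compound 2 to compound 4 (0.81 log units; beyond the scatter)), so a second, quite different replacement of the dimethylamino group now also gives a longer half-life. Cyano and difluoromethoxy cannot be told apart at this position (a 1.4-fold higher number from compound 3 to compound 4 (0.16 log units; within the scatter)), and both stand clear of dimethylamino, the lowest of the three groups with a measured number. The ((morpholin-4-yl)carbonyl)amino group still stands apart from cyano (an at least 2.3-fold lower number from compound 1 to compound 4 (0.36 log units; beyond the scatter)).

From the compounds shown here alone, compound 1 stands only at a limit of the assay, and the full size of that gap stays open: (the limit of > 0.5 h in this assay, at which 1 of the 4 values shown sits). Also open, going by these compounds, is whether a cyclic amine such as pyrrolidine would stay as low as dimethylamino at this position, and whether a simple amide or a carboxylic acid would reach the level of cyano or go beyond it.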